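Replacing methoxycarbonyl with methyl on the amide carbonyl

The source may hold more compounds than are shown below. What is called first, only, known or untested is meant among the compounds shown, and "the series" means these compounds.

Of the compounds shown here, three sharing one core have been measured in a functional assay on B16 cells (Mus musculus) for inhibition; a lower number here means a stronger inhibitor, a higher number a weaker inhibitor. Compound 1 `COc1cc(/C=C/C(=O)c2cccc(NC(=O)c3cc(Cl)cc(Cl)c3)c2)ccc1O` gives 4.83 ug/mL, compound 2 `COc1cc(/C=C/C(=O)c2cccc(NC(=O)c3ccc(Cl)cc3)c2)ccc1O` gives 0.59 ug/mL, and compound 3 `COC(=O)C(=O)Nc1cccc(C(=O)/C=C/c2ccc(O)c(OC)c2)c1` gives 4.41 ug/mL. Compound 3 thus stands with compound 1, and the measured step between them, a 1.1-fold lower number from compound 1 to compound 3 (0.04 log units; within the scatter), does not separate them. Compound 2 stands apart from both, and the step to compound 3 is a 7.5-fold higher number from compound 2 to compound 3 (0.87 log units; beyond the scatter).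

Compound 4 `COc1cc(/C=C/C(=O)c2cccc(NC(C)=O)c2)ccc1O` differs from compound 3 at one place: methyl in place of methoxycarbonyl on a carbonyl carbon. All three measured steps change the group at this same place. Only those involving the 4-chlorophenyl of compound 2 go beyond the scatter, the other being an 8.2-fold lower number from compound 1 to compound 2 (0.91 log units; beyond the scatter). The methoxycarbonyl of compound 3 and the 3,5-dichlorophenyl of compound 1 give values within the scatter of each other, although they are very different groups. Among the measured compounds shown here, no measured compound carries a methyl here, so the evidence is thin, and a shift as large as those seen with compound 2 cannot be excluded. The step expected is nevertheless small, a 1.3-fold lower number from compound 3 to compound 4 (0.10 log units; within the scatter), and no change beyond the scatter is foreseen. Compound 4 is estimated at 3.5 ug/mL, with an expected range of 1.2 ug/mL to 10 ug/mL.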

Compound 4, half-maximal inhibitory concentration: 3.62 ug/mL
Beside the measured number, compound 4's estimate is 1.0-fold (0.01 log units) below it; measured number inside the range.
By their numbers in this assay, from the lowest: compound 2; then compounds 4, 3 and 1 (each within the scatter of the next).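

With methyl on the carbonyl carbon, this assay gives a 1.2-fold lower number from compound 3 to compound 4 (0.09 log units; within the scatter), and likewise a 1.3-fold lower number from compound 1 to compound 4 (0.13 log units; within the scatter), so a group of one heavy atom with no ring cannot be told apart from the methoxycarbonyl or the 3,5-dichlorophenyl. Among these compounds, then, the 4-chlorophenyl remains the only group that stands apart, now also against the plain acetamido compound, with a 6.1-fold higher number from compound 2 to compound 4 (0.79 log units; beyond the scatter); compounds 1, 3 and 4 form one level despite their very different groups, and compound 2 is the one exception to it. No measurement at hand accounts for why compound 2 differs from the other three.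

On these data alone, what stays open is whether this separation belongs to the 4-chlorophenyl alone or would extend to an unsubstituted phenyl on the same carbonyl carbon, which would show whether the ring, its chlorine or the pattern of chlorines matters. As far as these compounds go, it is equally open whether a longer chain such as butyl, or a carboxylic acid in place of the methoxycarbonyl, would stay at the level of compounds 1, 3 and 4 or leave it.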